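Bromine added to the N-phenyl of compound 2: working notes

The compounds below may be only part of what the source reports. "The series", "measured", "known", "first", "only" and "open" are said of these compounds alone.

Compound 1 `Cc1cccc(N(C)S(=O)(=O)C2CC3OC2C(c2ccc(NC(=O)CCCCCCC(=O)O)cc2)=C3c2ccc(O)cc2)c1` sits at a limit in a functional assay on DU-145 cells (Homo sapiens) for antiproliferative activity, read by MTT assay, with a stated time of 72 h; on this read-out lower numbers stand for stronger inhibition and higher numbers for weaker inhibition: > 100000 nM.
Compound 2 `CCN(c1ccccc1)S(=O)(=O)C1CC2OC1C(c1ccc(NC(=O)CCCCCCC(=O)O)cc1)=C2c1ccc(O)cc1` sits at a limit in this assay: > 100000 nM.

For the measured compounds named here, both values are limits, so the one measured step, a step that the two limits leave unreadable from compound 1 to compound 2, is unreadable. Compound 2 therefore stands at the limit of > 100000 nM in this assay, at which 2 of the 2 values shown sit, with no number to its name and no scale of change anywhere in the pair.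

Compound 3 `CCN(c1ccccc1Br)S(=O)(=O)C1CC2OC1C(c1ccc(NC(=O)CCCCCCC(=O)O)cc1)=C2c1ccc(O)cc1` differs from compound 2 by bromo in place of hydrogen on an aromatic carbon, read one bond further out as phenyl to 2-bromophenyl on the sulfonamide nitrogen. Going by the values given here, no measured step bears on this change, and nothing shows any movement beyond the scatter. Compound 3 is accordingly expected to stay at the limit, estimated at 100000 nM within a range of 20000 nM to 500000 nM. The step of a number no higher from compound 2 to compound 3 (the limit leaves the size open) expected for compound 3 is none beyond the scatter.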

Compound 3, half-maximal inhibitory concentration: 95300 nM
Compound 3: the middle estimate sits 1.0-fold (0.02 log units) above what was measured; the range from low to high includes it.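

Bromo in place of hydrogen on an aromatic carbon, ortho to a large group, gives the series its first reading that is a number and not a limit in this assay: compound 3 gives 95300 nM. The bromo change yields an at least 1.0-fold lower number from compound 2 to compound 3 (0.02 log units; that floor lies within the scatter), and the wider exchange on the sulfonyl sulfur yields an at least 1.0-fold lower number from compound 1 to compound 3 (0.02 log units; that floor lies within the scatter), so neither change is shown to move the read-out beyond the scatter. The step between compound 1 and compound 2 still cannot be read, and both of those compounds remain limits: the limit of > 100000 nM in this assay, at which 2 of the 3 values shown sit.

From the compounds shown here alone, how far compound 1 and compound 2 actually lie from compound 3 remains open. Also open, going by these compounds, is whether chloro, methoxy or an amine on the same aromatic carbon would give a number in this assay, or a lower one.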